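This account rests on a few compounds, and the source may have more. Where it says the series, first, only, none or still open, it means among the compounds named here.

Compound 1, `Cn1c(Cc2nn(C)c(=O)c3ccccc23)nnc1SCCCCCCCC(=O)Nc1ccc(Cl)cc1Cl`, is the starting point. In an assay on 32D cells for inhibition of interleukin-15 (Mus musculus), read by resazurin assay, with stated times of 30 min and 2.5 days, in the presence of a further agent that is not named here (a lower number here means a stronger inhibitor, a higher number a weaker inhibitor), compound 1 gives 3900 nM. Among the measured compounds shown here, this is the only real number available here, since the other measured compound yields no number at all. Compound 2, `CCOC(CCn1c(Cc2nn(C)c(=O)c3ccccc23)nnc1SCC(=O)Nc1ccc(Cl)cc1Cl)OCC`, is built on the same core with a different chain and a different substituent. In this assay, for the measured compounds named here, compound 2 reaches only > 30000 nM, which is a limit of the assay rather than a measured number. the limit of > 30000 nM in this assay, at which 1 of the 2 values shown sits, therefore leaves compound 1 as the single compound with a measured value, and nothing can be said about how compound 2 compares with it in size.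

Compound 3, `Cn1nc(Cc2nnc(SCCCCCCCC(=O)Nc3ccc(Cl)cc3Cl)n2CCC=O)c2ccccc2c1=O`, is the next compound to be tested. It differs from compound 1 by formylmethyl in place of hydrogen on a saturated chain carbon bound to an aromatic nitrogen; the rest of the molecule stays as in compound 1. Going by the values given here, no measured pair in this set shows what such an addition does, so there is no step to lean on. The step expected here is a 1.5-fold higher number from compound 1 to compound 3 (0.19 log units; within the scatter), which amounts to a small weakening or no change beyond the usual scatter. Compound 3 is thus estimated at 6000 nM, with a range from 2000 nM to 25000 nM in this assay.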

Compound 3, half-maximal inhibitory concentration: 5500 nM
Beside the measured number, compound 3's estimate is 1.1-fold (0.04 log units) above it; the range from low to high includes it.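

Among the compounds shown here, this is the first step that can be read at this place, the saturated chain carbon bound to an aromatic nitrogen, and in this assay it reads a 1.4-fold higher number from compound 1 to compound 3 (0.15 log units; within the scatter). Swapping hydrogen for formylmethyl, which can also be read as methyl to 2-formylethyl, adds a short chain with a carbonyl and a hydrogen-bond acceptor, yet compound 3 cannot be told apart from compound 1 in this assay, so this one added group costs nothing measurable here. No measured property in the data shown accounts for this result.

Going by these compounds, a single pair speaks for a single group, so it remains open whether an amine, a carboxylic acid or a longer chain at this same place would also leave the number within the scatter, or would move it in either direction. For the compounds shown here, compound 2 differs from compound 1 in more than one place and gives only a limit, so it adds no step that could settle this, and how far this place can be changed before the number shifts is still unknown.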